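From furan-2-yl to 4-methoxyphenyl on a shared core

A few compounds are considered here, and "the series" means these few. Any claim that something is new, unique, unknown or untested is made for them only; others in the source may bear on it.

Measured so far in a functional assay on HCT-116 cells (Homo sapiens) for inhibition, read by sulforhodamine B assay, with a stated time of 48 h, tested at 50 uM; on this read-out higher numbers stand for more inhibition of growth at the one concentration tested and lower numbers for less inhibition of growth:
- compound 1 (`COc1ccccc1/C=C/C(=O)/C=C/c1ccc(OCc2cn(CCCOc3cc(=O)oc4ccccc34)nn2)c(OC)c1`): 53%
- compound 2 (`COc1cc(/C=C/C(=O)/C=C/c2ccco2)ccc1OCc1cn(CCCCOc2cc(=O)oc3ccccc23)nn1`): 47%

Among the compounds with values here, these are the only two numbers available, and they lie within the usual scatter of each other, so neither compound can be ranked above the other. Compound 3 (`COc1ccc(/C=C/C(=O)/C=C/c2ccc(OCc3cn(CCCCOc4cc(=O)oc5ccccc45)nn3)c(OC)c2)cc1`) has not yet been measured. It keeps the rest of compound 2 and differs from it in one place: 4-methoxyphenyl in place of furan-2-yl on a double-bonded chain carbon bound to a double-bonded chain carbon.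

Within the data shown here, compound 1 and compound 2 differ from each other in more than one place, so no measured pair isolates this change. In this assay, only a small upward move is expected, one that stays within the scatter. The expected change is a number 5 percentage points higher from compound 2 to compound 3 (within the scatter). For compound 3 the estimated value is 52%, with an expected range of 38% to 66%.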

Compound 3, percent growth inhibition at one concentration: 40%
Compound 3: middle estimate off by 12 percentage points, on the high side, within the range that was stated.
By their numbers in this assay, from the lowest: compounds 3, 2 and 1 (each within the scatter of the next, the first and the last beyond it).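

Putting 4-methoxyphenyl in place of furan-2-yl on a double-bonded chain carbon bound to a double-bonded chain carbon gives a number 7 percentage points lower from compound 2 to compound 3 (within the scatter) in this assay. Within the data shown here, this is the first pair that isolates the change, and it shows no difference clear of the usual scatter between a group of 5 heavy atoms and one of 8 at this position. Nothing at hand bears on what lies behind this step.

On these data alone, it remains open whether a different group in this place, such as an amine or a carboxylic acid, would give a step beyond the scatter. This change also rests on a single pair on one shared core, so whether it would read the same on another core is unsettled.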